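Moving the Chlorine One Carbon Out in Compound 4

The source may report more compounds than this note shows. Statements on the series, on what has been measured and on what is new or still open speak of the compounds shown alone.

Of the compounds shown here, three built on one shared core have been tested in a functional assay on HT-29 cells (Homo sapiens) for antiproliferative activity, read by sulforhodamine B assay, with a stated time of 48 h; a lower number here means a stronger inhibitor, a higher number a weaker inhibitor. Compound 1 `CCC(=O)Nc1ccc(S(=O)(=O)Oc2ccccc2I)cc1` gives 11000 nM, compound 2 `CCCCCC(=O)Nc1ccc(S(=O)(=O)Oc2ccccc2I)cc1` gives 13000 nM, and compound 3 `O=C(CCl)Nc1ccc(S(=O)(=O)Oc2ccccc2I)cc1` gives 4100 nM. Compound 3 holds the lowest number of the three: the steps of a 2.7-fold lower number from compound 1 to compound 3 (0.43 log units; beyond the scatter) and a 3.2-fold lower number from compound 2 to compound 3 (0.50 log units; beyond the scatter) both lie beyond the scatter, while the step of a 1.2-fold higher number from compound 1 to compound 2 (0.07 log units; within the scatter) lies within it.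

Compound 4 `O=C(CCCl)Nc1ccc(S(=O)(=O)Oc2ccccc2I)cc1` differs from compound 3 by chloromethyl in place of chloro on a saturated chain carbon bound to a carbonyl carbon. Going by the values given here, the steps that bear on this change are a 2.7-fold lower number from compound 1 to compound 3 (0.43 log units; beyond the scatter) and a 3.2-fold lower number from compound 2 to compound 3 (0.50 log units; beyond the scatter), where a chloro bound to a carbonyl carbon brought a modest lower number, and a 1.2-fold higher number from compound 1 to compound 2 (0.07 log units; within the scatter), where lengthening the chain alone made no difference beyond the scatter. Because a 2.7-fold lower number from compound 1 to compound 3 (0.43 log units; beyond the scatter) and a 3.2-fold lower number from compound 2 to compound 3 (0.50 log units; beyond the scatter) turned on the chloro sitting on the carbon bound to the carbonyl carbon, and compound 4 no longer has it there, a modest step upward in this assay is expected, a 2.0-fold higher number from compound 3 to compound 4 (0.29 log units; within the scatter). Compound 4 is therefore estimated at 8000 nM, within a range from 3000 nM to 20000 nM.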

Compound 4, half-maximal inhibitory concentration: 14000 nM
Compound 4: the middle estimate sits 1.8-fold (0.24 log units) below what was measured; the range from low to high includes it.
By their numbers in this assay, from the lowest: compound 3; then compounds 1, 2 and 4 (each within the scatter of the next).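

In this assay the position of the chlorine on the chain proves to matter: chloromethyl in place of chloro on a saturated chain carbon bound to a carbonyl carbon gives a 3.4-fold higher number from compound 3 to compound 4 (0.53 log units; beyond the scatter) in a modest step. The 2-chloroethyl group of compound 4 cannot be told apart from the chains without chlorine, as a 1.1-fold higher number from compound 2 to compound 4 (0.03 log units; within the scatter) and a 1.3-fold higher number from compound 1 to compound 4 (0.10 log units; within the scatter) both lie within the scatter, so among these four only the chloromethyl group of compound 3 stands apart. Nothing shown explains this difference.

The compounds shown leave open whether bromo, methoxy or an amine on that same carbon would match chloro. They also leave open whether a longer chain, such as 3-chloropropyl, would stay level with compound 4 in this assay or move away from it.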